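A few compounds are considered here, and "the series" means these few. Any claim that something is new, unique, unknown or untested is made for them only; others in the source may bear on it.

Measured in a functional assay on PC-3 cells (Homo sapiens) for cytotoxicity, read by cell counting, with a stated time of 48 h; a higher number here means a weaker inhibitor, a lower number a stronger inhibitor:
- Compound 1 `Cc1ccc(-n2cc(COc3cccc4cnc(Nc5cccc(Cl)c5)nc34)nn2)c([N+](=O)[O-])c1`: 7000 nM
- Compound 2 `Clc1ccc(-n2cc(COc3cccc4cnc(Nc5cccc(Cl)c5)nc34)nn2)cc1`: > 25000 nM

Compound 2 gives > 25000 nM, which is a limit and not a number. It sits at the limit of > 25000 nM in this assay, at which 1 of the 2 values shown sits.

Compound 3 `COc1ccccc1-n1cc(COc2cccc3cnc(Nc4cccc(Cl)c4)nc23)nn1` keeps the shared core and changes one group: 2-methoxyphenyl in place of 4-chlorophenyl on an aromatic nitrogen. The 2-methoxyphenyl takes the place of the 4-chlorophenyl on an aromatic nitrogen.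

Going by the values given here, only one measured step bears on this change: an at least 3.5-fold higher number from compound 1 to compound 2 (0.55 log units; beyond the scatter). It shows that a swap at this place can move the number in this assay, but it says nothing directly about 2-methoxyphenyl. No step beyond the scatter is therefore expected, with a slight lean towards a lower number and a real chance of another limit. The estimated step is an at least 1.5-fold lower number from compound 2 to compound 3 (0.19 log units; that floor lies within the scatter). For compound 3 the expected value is 16000 nM, with an estimated range of 6000 nM to 40000 nM.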

Compound 3, half-maximal inhibitory concentration: 8000 nM
Estimate against measurement, compound 3: 2.0-fold (0.30 log units) above, and the stated range covers the measured number.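

In this assay, the step from 4-chlorophenyl to 2-methoxyphenyl shows that the number at this position can also fall: an at least 3.1-fold lower number from compound 2 to compound 3 (0.49 log units; beyond the scatter). Compound 2 stands at a limit, not at a number, so that size is only a floor: the limit of > 25000 nM in this assay, at which 1 of the 3 values shown sits.

Compound 3 also holds a measurable value without the nitro group of compound 1, and the two compounds lie within the scatter of each other: a 1.1-fold higher number from compound 1 to compound 3 (0.06 log units; within the scatter).

On these data alone, what the methoxy group itself contributes remains open, as does whether its place on the phenyl ring matters. A plain phenyl or a phenyl carrying an amine would help to separate the effect of the added group from that of the 4-chloro group's removal.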